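Compound 2 to compound 4: a step in a flat series

A few compounds are considered here, and "the series" means these few. Any claim that something is new, unique, unknown or untested is made for them only; others in the source may bear on it.

Three compounds on one shared core have numbers in a functional assay, read by spectrophotometry, with a stated time of 15 min; a lower number here means a stronger inhibitor, a higher number a weaker inhibitor. Compound 1 (`Cc1nc2c3ccccc3ccc2c2nc3c(ccc4ccccc43)c(-c3cccc([N+](=O)[O-])c3)c12`) gives 54.2 ug/mL, compound 2 (`Cc1nc2c3ccccc3ccc2c2nc3c(ccc4ccccc43)c(-c3nccnc3N)c12`) gives 47.8 ug/mL and compound 3 (`Cc1nc2c3ccccc3ccc2c2nc3c(ccc4ccccc43)c(-c3cc([N+](=O)[O-])ccc3N)c12`) gives 43.3 ug/mL. Compound 2 thus stands within the scatter of both others, and no order can be read among the three.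

Compound 4 (`Cc1nc2c3ccccc3ccc2c2nc3c(ccc4ccccc43)c(-c3ccccc3N)c12`) has no number yet. It carries 2-aminophenyl in place of 3-aminopyrazin-2-yl on an aromatic carbon, opposite the ring nitrogen: 2-aminophenyl in place of 3-aminopyrazin-2-yl on an aromatic carbon.

The nearest measured precedent is a 1.1-fold lower number from compound 2 to compound 3 (0.04 log units; within the scatter), where the same 3-aminopyrazin-2-yl gives way to 2-amino-5-nitrophenyl. The other two measured steps are a 1.1-fold lower number from compound 1 to compound 2 (0.05 log units; within the scatter), which brings in 3-aminopyrazin-2-yl in place of 3-nitrophenyl, and a 1.3-fold lower number from compound 1 to compound 3 (0.10 log units; within the scatter), which puts amino in place of hydrogen on an aromatic carbon. All three lie within the scatter, although three compounds are a thin basis. No step beyond the scatter, in either direction, is therefore expected in this assay. The expected change is a 1.0-fold lower number from compound 2 to compound 4 (0.02 log units; within the scatter). For compound 4 the estimate is 46 ug/mL, with an expected range of 28 ug/mL to 75 ug/mL.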

Compound 4, half-maximal inhibitory concentration: 45.6 ug/mL
The estimate for compound 4 lay 1.0-fold (0.00 log units) above the measured number; the range from low to high includes it.
By their numbers in this assay, from the lowest: compounds 3, 4, 2 and 1 (each within the scatter of the next).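

In this assay, replacing 3-aminopyrazin-2-yl with 2-aminophenyl at this aromatic carbon, opposite the ring nitrogen, gives a 1.0-fold lower number from compound 2 to compound 4 (0.02 log units; within the scatter), so a six-membered aromatic ring of carbon only and one with 2 hetero atoms cannot be told apart here when each carries the amino group. Hydrogen in place of nitro on the aminophenyl ring gives a 1.1-fold higher number from compound 3 to compound 4 (0.02 log units; within the scatter), which shows that the series holds within the scatter with or without that nitro group. 2-Aminophenyl in place of 3-nitrophenyl gives a 1.2-fold lower number from compound 1 to compound 4 (0.08 log units; within the scatter), and with this step all pairs among the four compounds on the shared core lie within the scatter, so none of these aromatic groups at this position separates from the others.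

Nothing available bears on why the numbers at this position stay so close. From the compounds shown here alone, it remains open whether a group of another kind at this carbon, such as a carboxylic acid, a morpholine or a simple methyl in place of the aromatic ring, would give a step beyond the scatter.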